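Boron Heterocycle Amides: From Iodophenyl to Methylsulfanyl Biaryl

This account rests on a few compounds, and the source may have more. Where it says the series, first, only, none or still open, it means among the compounds named here.

Compound 1 `CC(C)(C)NC(=O)CCc1cccc2c1B(O)OC2` gives in a functional assay on SK-OV-3 cells (Homo sapiens) for antiproliferative activity, read by MTT assay, with a stated time of 72 h (a higher number here means a weaker inhibitor, a lower number a stronger inhibitor), only a limit, > 100000 nM.
Compound 2 `Cc1ccc(NC(=O)CCc2cccc3c2B(O)OC3)cc1` gives in this assay 860 nM.
Compound 3 `O=C(CCc1cccc2c1B(O)OC2)Nc1cccc(I)c1` gives in this assay 630 nM.

Compound 3 holds the lowest of the two numbers measured, though the step of a 1.4-fold lower number from compound 2 to compound 3 (0.14 log units; within the scatter) lies within the scatter. Compound 4 `CSc1ccc(-c2cccc(NC(=O)CCc3cccc4c3B(O)OC4)c2)cc1` differs from compound 3 by 4-(methylsulfanyl)phenyl in place of iodo on an aromatic carbon. Within the data shown here, the steps that bear on this are the two from the tert-butyl amide, an at least 110-fold lower number from compound 1 to compound 2 (2.06 log units; beyond the scatter) and an at least 150-fold lower number from compound 1 to compound 3 (2.20 log units; beyond the scatter), which show that an aryl group on the amide nitrogen matters greatly, while the exchange of one aryl substituent for another stayed within the scatter. Among the measured compounds shown here, no measured step swaps a ring substituent for a second aromatic ring, so the expectation rests on the aryl amide being kept: a step of a 1.1-fold lower number from compound 3 to compound 4 (0.02 log units; within the scatter) is expected, within the scatter. Compound 4 is therefore estimated at 600 nM, between 150 nM and 2500 nM.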

Compound 4, half-maximal inhibitory concentration: 140 nM
Compound 4: middle estimate off by 4.3-fold (0.63 log units), on the high side, and the stated range ends above it.
By their numbers in this assay, from the lowest: compound 4; then compounds 3 and 2 (each within the scatter of the next). At a limit, above all of these: compound 1.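

In this assay, 4-(methylsulfanyl)phenyl in place of iodo gives a 4.5-fold lower number from compound 3 to compound 4 (0.65 log units; beyond the scatter), the only step shown beyond the scatter among compounds that keep an aryl group on the amide nitrogen. This aromatic carbon therefore accepts a second aromatic ring, and the change lowers the number, whereas the exchange between compound 2 and compound 3 did not separate them. Nothing shown accounts for this step.

Going by these compounds, it remains open whether the ring alone suffices or the methylsulfanyl group contributes, as an unsubstituted phenyl would show. On these data alone, a methoxy group, an amine or a carboxylic acid at that outer ring also remains untested here.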